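Methyl on the amide nitrogen chain of a quinolone carboxamide

The source may hold more compounds than are shown below. What is called first, only, known or untested is meant among the compounds shown, and "the series" means these compounds.

Measured compounds:
- compound 1, `CSc1ccc2c(c1)c(O)c(C(=O)N(C)c1ccccc1)c(=O)n2C`: 100%
- compound 2, `CSc1ccc2c(c1)c(O)c(C(=O)N(C)c1ccccc1)c(=O)n2Cc1ccccc1`: -66%

In a functional assay on the whole organism for inhibition, with Mus musculus as the target, at a dose of 32 mg/kg by the oral route (on this read-out lower numbers stand for less inhibition and higher numbers for more inhibition at the one dose given (going by the name of the read-out)), compound 1 gives 100%, the highest of the two numbers, and compound 2 gives -66%. Among the measured compounds shown here, the one measured step runs a number 166 percentage points lower from compound 1 to compound 2 (beyond the scatter), a change at the carbon bound to the aromatic nitrogen, not at the amide nitrogen. Compound 3, `CCN(C(=O)c1c(O)c2cc(SC)ccc2n(C)c1=O)c1ccccc1`, differs from compound 1 by methyl in place of hydrogen on a saturated chain carbon bound to an amide-type nitrogen, a change in a different place and of a smaller group than the measured step. That step therefore bears on it only loosely; it shows that the shared core can lose its activity on substitution, but the group here is small. The expectation for compound 3 is a modest fall, a number 25 percentage points lower from compound 1 to compound 3 (beyond the scatter), with wide uncertainty. Compound 3 is thus estimated at 75%, in the range 25% to 100%.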

Compound 3, a percentage reported as inhibition, in the whole organism at one dose (the size of the read-out at that dose, not a potency): 89%
The estimate for compound 3 lay 14 percentage points below the measured number; measured number inside the range.
By their numbers in this assay, from the lowest: compound 2; then compound 3; then compound 1.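

Here the change sits on a saturated chain carbon bound to an amide-type nitrogen, and going from methyl to ethyl in this assay gives a number 11 percentage points lower from compound 1 to compound 3 (beyond the scatter) at the one oral dose tested. Among the compounds shown here, compound 3 still gives 89% in this read-out, so this position accepts one added methyl with most of the inhibition kept, whereas the only earlier step, a number 166 percentage points lower from compound 1 to compound 2 (beyond the scatter) after a phenyl was added at a different place, took the number far lower. No measurement shown offers a reason for the size of the new step.

As far as these compounds go, whether a longer chain such as propyl would keep the inhibition at this place remains open. So does the effect of a chain ending in an amine or a carboxylic acid.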